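The source may report more compounds than this note shows. Statements on the series, on what has been measured and on what is new or still open speak of the compounds shown alone.

Compound 3, `O=Cc1ccc(-c2cn3ccnc3c(-c3ccc4ncn(Cc5ccccc5)c4c3)n2)cc1`, belongs to a set of three compounds that share a core and differ at two outer positions. In a functional assay on KM12 cells (Homo sapiens) for inhibition, read by sulforhodamine B assay, with a stated time of 48 h, tested at 10 uM (a lower number here means less inhibition, a higher number more inhibition at the concentration tested (going by the name of the read-out)), compound 3 gives 3.69%, the lowest of the three numbers shown. Compound 1, `c1ccc2c(-c3cn4ccnc4c(-c4ccc5ncn(C6CCCCC6)c5c4)n3)cccc2c1`, gives 11.1%, which lies within the scatter of the value of compound 3. Going by the values given here, compound 2, `CCc1ccc(-c2cn3ccnc3c(-c3ccc4ncn(Cc5ccccc5)c4c3)n2)cc1`, gives 45.7%, and the single measured step, a number 42 percentage points lower from compound 2 to compound 3 (beyond the scatter), is the only one beyond the scatter in this set.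

Compound 4, `c1ccc(Cn2cnc3ccc(-c4nc(-c5cccc6ccccc56)cn5ccnc45)cc32)cc1`, differs from compound 3 in one place: naphthalen-1-yl in place of 4-formylphenyl on an aromatic carbon. Among the compounds with values here, no measured step covers this exchange directly. The step of a number 42 percentage points lower from compound 2 to compound 3 (beyond the scatter) concerns the same position but a different pair of groups, so it bears on compound 4 only indirectly. Compound 1 carries the naphthalen-1-yl group that enters here and gives 11.1%, a value within the scatter of compound 3. Compound 4 is therefore expected to show no step beyond the scatter, a number 8.3 percentage points higher from compound 3 to compound 4 (within the scatter). The estimate for compound 4 is 12%, with a range from 0% to 35%.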

Compound 4, a percentage reported as inhibition, at one concentration (the size of the read-out at that concentration, not a potency): 11%
Estimate against measurement, compound 4: 1 percentage points above; the range from low to high includes it.
By their numbers in this assay, from the lowest: compounds 3, 4 and 1 (each within the scatter of the next); then compound 2.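

In this assay, naphthalen-1-yl in place of 4-formylphenyl on the aromatic carbon gives a number 7.3 percentage points higher from compound 3 to compound 4 (within the scatter), while naphthalen-1-yl in place of 4-ethylphenyl gives a number 34.7 percentage points lower from compound 2 to compound 4 (beyond the scatter). With benzyl on the aromatic nitrogen, 4-ethylphenyl thus stands apart at this position from the other two groups, which cannot be told apart. The other position can now be read as well: benzyl in place of cyclohexyl on the aromatic nitrogen, with naphthalen-1-yl kept, gives a number 0.1 percentage points lower from compound 1 to compound 4 (within the scatter).

Going by these compounds, whether a carboxylic acid or a longer chain in place of the ethyl of 4-ethylphenyl would keep the number of compound 2 remains open, as does whether cyclohexyl and benzyl would also match alongside 4-ethylphenyl. Nothing available explains why 4-ethylphenyl differs from the other two groups.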